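Compound 4 tests a pyridyl swap on the biaryl

A few compounds are considered here, and "the series" means these few. Any claim that something is new, unique, unknown or untested is made for them only; others in the source may bear on it.

Compound 1 `Cc1cccc(C)c1-c1cccc(COc2ccc(CCC(=O)O)cc2)c1` gives 8 nM in a functional assay on cells for agonist activity at Free fatty acid receptor 1 (Homo sapiens), read by calcium flux; on this read-out lower numbers stand for an effect already at smaller amounts and higher numbers for an effect only at larger amounts of compound. Compound 2 `Cc1cccc(C)c1-c1cccc(COc2ccc(CCC(=O)O)s2)c1` gives 32 nM. Compound 3 `Cc1cccc(C)c1-c1cccc(COc2ccc(CC3SC(=O)NC3=O)s2)c1` gives 82 nM.

Among these three numbers compound 2 stands second highest: compound 1 shows a lower number, and compound 3 lies above it by a 2.6-fold higher number from compound 2 to compound 3 (0.41 log units; beyond the scatter). Compound 4 `O=C(O)CCc1ccc(OCc2cccc(-c3ccncc3Cl)c2)s1` differs from compound 2 only at the biaryl end: 3-chloropyridin-4-yl in place of 2,6-dimethylphenyl on an aromatic carbon. For the measured compounds named here, no measured step touches this group; the single measured step, a 2.6-fold higher number from compound 2 to compound 3 (0.41 log units; beyond the scatter), concerns the acid end of the molecule and so says nothing direct about the change here. Going by the values given here, with no comparable step in hand, a modest rise in the number is expected for compound 4, a 2.0-fold higher number from compound 2 to compound 4 (0.31 log units; beyond the scatter). Compound 4 is therefore estimated at 65 nM, within a range of 15 nM to 280 nM.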

Compound 4, half-maximal effective concentration: 2010 nM
For compound 4 the middle estimate is 31-fold (1.49 log units) below the measured one; the whole stated range lies below it.
By their numbers in this assay, from the lowest: compound 1; then compound 2; then compound 3; then compound 4.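

At this position on the shared core, the change from 2,6-dimethylphenyl to 3-chloropyridin-4-yl is far from neutral: in this assay it brings a 63-fold higher number from compound 2 to compound 4 (1.80 log units; beyond the scatter), a large step where the earlier measured change at the acid end was modest. The entering group has a ring with one hetero atom and one hydrogen-bond acceptor, while the leaving group has neither. Nothing measured here gives a cause for this step. The ring nitrogen and the chlorine enter together, so the compounds shown leave open how much of the step belongs to each. A 3-methylpyridin-4-yl or a 2-chlorophenyl group at this place would separate the two.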